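Changing the Aryl Partner on the Shared Core

The source may report more compounds than this note shows. Statements on the series, on what has been measured and on what is new or still open speak of the compounds shown alone.

Measured compounds:
compound 1 `O=S(=O)(c1cc(Cl)cc(Cl)c1)c1cnc2c(F)cccc2c1-c1ccc(F)cc1` gives 1.01 mL/min
compound 2 `COc1cccc(-c2c(S(=O)(=O)c3cc(F)cc(F)c3)cnc3c(F)cccc23)c1` gives 2.76 mL/min
compound 3 `O=S(=O)(c1cc(Cl)cc(Cl)c1)c1cnc2c(F)cccc2c1-c1ccccc1F` gives 0.44 mL/min

All three numbers come from an ADME assay on microsomes from liver (Homo sapiens) for metabolic stability, tested at 2.5 uM; a lower number here means slower removal, a higher number faster removal of the compound. For the measured compounds named here, compound 3 stands lowest of the three: compound 1 sits above it, and the one directly comparable pair shows a 2.3-fold lower number from compound 1 to compound 3 (0.36 log units; beyond the scatter), a modest step. Compound 2 gives the highest number of the set, but it differs from compound 3 in two places, so its value gives only a loose hint.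

Compound 4 `COc1cccc(-c2c(S(=O)(=O)c3cc(Cl)cc(Cl)c3)cnc3c(F)cccc23)c1` is the next step from compound 3. The change is 3-methoxyphenyl in place of 2-fluorophenyl on an aromatic carbon. Going by the values given here, no measured step covers this exact swap; the step from compound 1 to compound 3 only moved a fluorine within the phenyl ring, whereas here a 3-methoxyphenyl enters. Compound 2, which also carries a 3-methoxyphenyl, shows a high number, so a rise is expected for compound 4, estimated at a 3.2-fold higher number from compound 3 to compound 4 (0.50 log units; beyond the scatter). Compound 4 is therefore expected to give about 1.4 mL/min in this assay, within roughly 0.6 mL/min to 3.5 mL/min.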

Compound 4, intrinsic clearance in a liver preparation (reported as CLH), per the amount of preparation that the assay uses: 2.31 mL/min
Estimate against measurement, compound 4: 1.7-fold (0.22 log units) below, within the range that was stated.
By their numbers in this assay, from the lowest: compound 3; then compound 1; then compounds 4 and 2 (each within the scatter of the next).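

Among the groups on this aromatic carbon, with the 3,5-dichlorophenyl sulfonyl part held fixed, 3-methoxyphenyl stands highest in this assay: replacing 2-fluorophenyl gives a 5.3-fold higher number from compound 3 to compound 4 (0.72 log units; beyond the scatter), and replacing 4-fluorophenyl gives a 2.3-fold higher number from compound 1 to compound 4 (0.36 log units; beyond the scatter). For the compounds shown here, the result also offers the first reading of the group on the sulfonyl sulfur, where 3,5-dichlorophenyl in place of 3,5-difluorophenyl gives a 1.2-fold lower number from compound 2 to compound 4 (0.08 log units; within the scatter), so with 3-methoxyphenyl present the two groups cannot be told apart in this assay. Nothing available here explains why these aryl groups give different numbers.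

From the compounds shown here alone, it remains open whether the sulfonyl swap would also make no clear difference with 2-fluorophenyl or 4-fluorophenyl on the aromatic carbon. Going by these compounds, how an amine or a carboxylic acid on that aryl ring would compare also remains open.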